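Lengthening the Amine Substituent from Methyl to Ethyl

The source may report more compounds than this note shows. Statements on the series, on what has been measured and on what is new or still open speak of the compounds shown alone.

Two compounds built on a shared core have been examined in an assay on cells for inhibition of Amine oxidase [flavin-containing] A (Homo sapiens), read by fluorescence, with a stated time of 30 min, tested at 10 uM; a higher number here means more inhibition at the concentration tested (going by the name of the read-out), a lower number less inhibition. Compound 1 `COc1ccccc1CN(C)Cc1ccc(/C=C2\Oc3cc(OC)c(OC)cc3C2=O)cc1O` gives 16.3% in this assay. Compound 2 `COc1cc2c(cc1OC)C(=O)/C(=C/c1ccc(CN(C)Cc3ccccc3)c(O)c1)O2` gives 19.4% in this assay. Among the compounds with values here, the single measured step, a number 3.1 percentage points higher from compound 1 to compound 2 (within the scatter), accompanies hydrogen in place of methoxy on an aromatic carbon, and it lies within the scatter, so the two numbers cannot be told apart. Compound 2 therefore stands at a level the measurements do not separate from compound 1.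

Compound 3 `CCN(Cc1ccccc1)Cc1ccc(/C=C2\Oc3cc(OC)c(OC)cc3C2=O)cc1O` differs from compound 2 by methyl in place of hydrogen on a saturated chain carbon bound to an amine nitrogen. Within the data shown here, no measured step touches this part of the molecule; the only step, a number 3.1 percentage points higher from compound 1 to compound 2 (within the scatter), concerns a different place and was itself within the scatter. The expectation is therefore no step beyond the scatter, a number 0.4 percentage points lower from compound 2 to compound 3 (within the scatter). Compound 3 is estimated at 19% in this assay, expected between 5% and 35%.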

Compound 3, a percentage reported as inhibition, at one concentration (the size of the read-out at that concentration, not a potency): 17%
The estimate for compound 3 lay 2 percentage points above the measured number; the range from low to high includes it.
By their numbers in this assay, from the lowest: compounds 1, 3 and 2 (each within the scatter of the next).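

Measured by this assay the change from methyl to ethyl on the amine gives a number 2.4 percentage points lower from compound 2 to compound 3 (within the scatter) and so adds one carbon to this amine substituent without any difference the measurements can resolve. A larger change in the same part of the molecule, benzyl(ethyl)amino in place of (2-methoxybenzyl)(methyl)amino, gives a number 0.7 percentage points higher from compound 1 to compound 3 (within the scatter) and so these two amine groups cannot be told apart in this read-out either. No supporting measurement is available that could explain why the numbers stay level.

The compounds shown leave open whether a longer chain on the amine nitrogen, such as propyl or butyl, would move the number beyond the scatter. They also leave open what a ring amine such as piperidine would do in place of the benzyl-bearing amine.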